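Cyano in Place of Acetyl: An Expected Shift in Growth Inhibition

The source may hold more compounds than are shown below. What is called first, only, known or untested is meant among the compounds shown, and "the series" means these compounds.

Of the compounds shown here, three have been measured in a functional assay on OVCAR-3 cells (Homo sapiens) for inhibition, read by sulforhodamine B assay, with a stated time of 48 h; on this read-out higher numbers stand for weaker inhibition of growth and lower numbers for stronger inhibition of growth. Compound 1 `COc1ccc(-c2[nH]c3ccccc3c2/C=C(\C#N)S(=O)(=O)c2ccccc2)cc1` gives 244 nM, compound 2 `COc1ccc2[nH]c(-c3ccccc3)c(C=C(C#N)C#N)c2c1` gives 3100 nM, and compound 3 `CC(=O)/C(=C\c1c(-c2ccccc2)[nH]c2ccccc12)S(=O)(=O)c1ccccc1` gives 1600 nM. Among these three numbers compound 3 stands second highest; it sits within the scatter of compound 2, while compound 1 lies lower by a margin beyond the scatter. Compound 4 `N#C/C(=C\c1c(-c2ccccc2)[nH]c2ccccc12)S(=O)(=O)c1ccccc1` differs from compound 3 in one place: cyano in place of acetyl on a double-bonded chain carbon bound to a double-bonded chain carbon and a sulfonyl sulfur. Among the measured compounds shown here, no measured pair shows this step, so its size can only be estimated. Compound 1, which also carries a cyano group on a double-bonded chain carbon, gives 244 nM and points toward stronger inhibition. Compound 4 is therefore expected to give 450 nM, between 150 nM and 1300 nM. The expected step is a 3.6-fold lower number from compound 3 to compound 4 (0.55 log units; beyond the scatter), beyond the scatter but modest.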

Compound 4, concentration for 50% growth inhibition: 1400 nM
Beside the measured number, compound 4's estimate is 3.1-fold (0.49 log units) below it, outside the stated range (above it).
By their numbers in this assay, from the lowest: compound 1; then compounds 4, 3 and 2 (each within the scatter of the next, the first and the last beyond it).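

At the double-bonded chain carbon bound to a double-bonded chain carbon and a sulfonyl sulfur, cyano in place of acetyl hardly moves the number (a 1.1-fold lower number from compound 3 to compound 4 (0.06 log units; within the scatter)). The larger difference appears instead with hydrogen in place of methoxy on an aromatic carbon (a 5.7-fold higher number from compound 1 to compound 4 (0.76 log units; beyond the scatter)). No supporting data explain either step.

On these data alone, whether an amine, a carboxylic acid or a longer chain at that chain carbon would also leave the number unmoved remains open. So does whether methoxy would bring a similar difference on compound 3.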